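Notes: phenylsulfonyl replaces the ether chain on compound 2

The source may hold more compounds than are shown below. What is called first, only, known or untested is meant among the compounds shown, and "the series" means these compounds.

- compound 1 (`C=CCCCCCOc1ncc(-c2ccccc2OCCCCC=C)n1C`) gives 79000 nM
- compound 2 (`C=CCCCCOc1ccccc1-c1cnc(OCCOCC=C)n1C`) gives 59000 nM

Both values come from a functional assay on SK-MEL-28 cells (Homo sapiens) for inhibition, read by colorimetric assay and MTT assay, with a stated time of 72 h (on this read-out lower numbers stand for stronger inhibition and higher numbers for weaker inhibition), and only these two compounds have been measured. Compound 2 stands level with compound 1 within the scatter, so neither can be ranked ahead of the other.

Compound 3 (`C=CCCCCOc1ccccc1-c1cnc(S(=O)(=O)c2ccccc2)n1C`) is the next to be read. It has phenylsulfonyl in place of 2-(allyloxy)ethoxy on an aromatic carbon, between two ring nitrogen atoms (phenylsulfonyl in place of 2-(allyloxy)ethoxy on an aromatic carbon). The rest of compound 2 stays unchanged.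

Going by the values given here, one measured step bears on this, and only weakly. It is a 1.3-fold lower number from compound 1 to compound 2 (0.13 log units; within the scatter) and it alters the same substituent, but it exchanges one open chain for another. Among the compounds with values here, no measured compound carries an aromatic group at this place, so the data give neither a firm size nor a firm direction. A modest move towards lower numbers is expected, with a wide margin, and the estimated step is (a 2.4-fold lower number from compound 2 to compound 3 (0.37 log units; beyond the scatter)). In this assay compound 3 is estimated at 25000 nM (expected range 6000 nM to 90000 nM).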

Compound 3, half-maximal inhibitory concentration: 38000 nM
Compound 3: middle estimate off by 1.5-fold (0.18 log units), on the low side, and the stated range covers the measured number.
By their numbers in this assay, from the lowest: compounds 3, 2 and 1 (each within the scatter of the next, the first and the last beyond it).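

In this assay, going by these compounds alone, the carbon between two ring nitrogen atoms now carries an aromatic group for the first time, and phenylsulfonyl in place of the open 2-(allyloxy)ethoxy chain gives a 1.6-fold lower number from compound 2 to compound 3 (0.19 log units; within the scatter); compound 2 and compound 3 therefore cannot be separated, even though the incoming group brings a six-membered aromatic ring and a sulfur atom. Within the data shown here, measured against the (hept-6-en-1-yl)oxy chain, the same phenylsulfonyl group gives a 2.1-fold lower number from compound 1 to compound 3 (0.32 log units; beyond the scatter), which is modest but is the only step in this set beyond the scatter, while compound 2 lies within the scatter of both neighbours. No measurement at hand gives a reason for either step.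

The phenylsulfonyl group joins its sulfonyl link and its phenyl ring in one change, so the contribution of each stays unresolved, and a methylsulfonyl group or a phenyl ring set directly on this carbon would separate them. Going by these compounds, it also remains open whether an amine or a carboxylic acid at this carbon would shift the number beyond the scatter from compound 2.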